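A Small Chain Extension Repeated on a Second Core

The compounds below may be only part of what the source reports. "The series", "measured", "known", "first", "only" and "open" are said of these compounds alone.

Compound 1 `Cc1ccc2c(c1)[n+]([O-])c(NCCN1CCCCC1)n[n+]2[O-]` and compound 2 `CCc1ccc2c(c1)[n+]([O-])c(NCCN1CCCCC1)n[n+]2[O-]` share one core and differ at a single point. In a functional assay on SiHa cells (Homo sapiens) for cytotoxicity, with a stated time of 4 h (a lower number here means a stronger inhibitor, a higher number a weaker inhibitor), compound 1 gives 2200 nM, while compound 2 gives 1000 nM. The change between them is methyl in place of hydrogen on a saturated chain carbon bound to an aromatic carbon and the step it made is a 2.2-fold lower number from compound 1 to compound 2 (0.34 log units; beyond the scatter). Compound 3 `COc1ccc2c(c1)[n+]([O-])c(NCCN(C)C)n[n+]2[O-]` carries a different core; the difference between the two cores is not broken down here. In this assay compound 3 gives 2900 nM, a gap to compound 1 that lies within the scatter and a gap to compound 2 that lies beyond it. Compound 4 `CCOc1ccc2c(c1)[n+]([O-])c(NCCN(C)C)n[n+]2[O-]` is not yet measured and differs from compound 3 by methyl in place of hydrogen on a saturated chain carbon bound to an oxygen on an aromatic ring. This is the same kind of change as that between compound 1 and compound 2, but not the same: there the saturated chain carbon is bound to an aromatic carbon, here it is bound to an oxygen on an aromatic ring. Because of the step of a 2.2-fold lower number from compound 1 to compound 2 (0.34 log units; beyond the scatter), a step of a 1.9-fold lower number from compound 3 to compound 4 (0.29 log units; within the scatter) is expected in this assay, with the different surroundings leaving room for a smaller or larger move. Compound 4 is estimated at 1500 nM, between 700 nM and 3500 nM.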

Compound 4, half-maximal inhibitory concentration: 800 nM
Estimate against measurement, compound 4: 1.9-fold (0.27 log units) above; the measured number falls inside the stated range.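

In this assay, methyl in place of hydrogen on a saturated chain carbon bound to an oxygen on an aromatic ring gave a 3.6-fold lower number from compound 3 to compound 4 (0.56 log units; beyond the scatter). Set beside the earlier step, the change moves the number the same way on both cores, and the two steps cannot be told apart in size: the same change on two cores in this assay, a 2.2-fold lower number (0.34 log units; beyond the scatter) from compound 1 to compound 2 and a 3.6-fold lower number (0.56 log units; beyond the scatter) from compound 3 to compound 4, 1.6-fold (0.22 log units) apart, within the scatter of two such steps This agreement rests on only two pairs, with the chain carbon bound to an aromatic carbon in one and to an oxygen on an aromatic ring in the other, so it does not show that the change would carry to any further core, nor does it explain why the number falls.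

The compounds shown leave open whether a longer chain, such as propyl or propoxy, would extend the same move or reverse it. They also leave open how an amine or a carboxylic acid at the same place would compare with methoxy and ethoxy.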